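The compounds below may be only part of what the source reports. "The series", "measured", "known", "first", "only" and "open" are said of these compounds alone.

Compound 1 `COc1ccc2[nH]c(C(=O)N3CC(=O)N(Cc4ccccc4)[C@@H](CN4CCCCC4)C3)cc2c1` is the reference point here. In an ADME assay on Vero cells (Chlorocebus sabaeus) for cytotoxicity, with a stated time of 7 days (a lower number here means that less compound is tolerated, a higher number that more compound is tolerated), compound 1 gives 76900 nM, the highest of the three numbers available. Compound 3 `COc1ccc2[nH]c(C(=O)N3CC(=O)N(Cc4cccc(OC(F)F)c4)[C@@H](CN4CCCCC4)C3)cc2c1` gives 12100 nM, and compound 2 `Cc1ccc2[nH]c(C(=O)N3CC(=O)N(Cc4ccccc4)[C@@H](CN4CCC5(CCC5)CC4)C3)cc2c1` gives 7800 nM. The measured step of a 6.4-fold lower number from compound 1 to compound 3 (0.80 log units; beyond the scatter) touches the aromatic side of the molecule, not the saturated amine end, so it does not speak directly to compound 4 `COc1ccc2[nH]c(C(=O)N3CC(=O)N(Cc4ccccc4)[C@@H](CN4CC5CCCC5C4)C3)cc2c1`. Compound 4 differs from compound 1 in this way: a group of 8 heavy atoms (7 carbon, 1 nitrogen; one five-membered non-aromatic ring of carbon only, one five-membered non-aromatic ring with 1 hetero atom) in place of a group of 6 heavy atoms (5 carbon, 1 nitrogen; one six-membered non-aromatic ring with 1 hetero atom), on a saturated chain carbon bound to a saturated ring carbon. Compound 2 carries a larger amine too, but also a different aromatic substituent, so its lower number can only hint. A modest drop is expected, with a 2.6-fold lower number from compound 1 to compound 4 (0.41 log units; beyond the scatter). Compound 4 is therefore estimated at 30000 nM, with a range from 10000 nM to 90000 nM.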

Compound 4, half-maximal cytotoxic concentration: 10600 nM
Beside the measured number, compound 4's estimate is 2.8-fold (0.45 log units) above it, and the stated range covers the measured number.
By their numbers in this assay, from the lowest: compounds 2, 4 and 3 (each within the scatter of the next); then compound 1.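

In this assay, changing only the amine end of the molecule has a clear effect: a 7.3-fold lower number from compound 1 to compound 4 (0.86 log units; beyond the scatter), with the aromatic side left untouched. Within the data shown here, the one earlier single-place step lay on the aromatic side, so this is the first direct sign that the group on this saturated chain carbon also affects how much compound the cells tolerate. No available evidence explains the effect of replacing piperidin-1-yl. As far as these compounds go, how morpholine or pyrrolidine would read at this place remains open. So does whether the same step would hold with difluoromethoxy on the aromatic side.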